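The compounds below may be only part of what the source reports. "The series", "measured", "known", "first", "only" and "open" are said of these compounds alone.

Working notes on the series. In an ADME assay on microsomes from liver (Rattus norvegicus) for metabolic stability, read by LC-MS, with a stated time of 10 min, tested at 0.5 uM (a higher number here means that more of the compound is left, a lower number that less of the compound is left), compound 1 (`CC(C)N1CCN(CCCN(C[C@H]2Cc3ccccc3CN2)[C@H]2CCCc3cccnc32)CC1`) gives 4% and stands lowest of the three measured compounds, with gaps beyond the scatter to compound 2 (`c1cnc2c(c1)CCC[C@@H]2N(CCCN1CCNCC1)Cc1nc2ccccc2[nH]1`), which gives 29% here, and to compound 3 (`c1cnc(CN(CCCN2CCNCC2)[C@H]2CCCc3cccnc32)nc1`), which gives 68% here.

The next compound to be read is compound 4 (`CN1CCN(CCCN(C[C@H]2Cc3ccccc3CN2)[C@H]2CCCc3cccnc32)CC1`). It keeps the core of compound 1 and differs in one place (methyl in place of isopropyl on an amine nitrogen in a ring), with methyl in place of isopropyl on an amine nitrogen in a ring, or 4-isopropylpiperazin-1-yl to 4-methylpiperazin-1-yl.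

Going by the values given here, the only measured single-place step is a number 39 percentage points higher from compound 2 to compound 3 (beyond the scatter) and it is large, but it concerns another place in the structure and other groups. Among the compounds with values here, it shows that this read-out can move far, yet no measured step touches the group on the ring nitrogen, so the data give no direct guide to this change. With compound 1 at 4% there is little room for a lower number, so any visible movement is expected upward.

The expected change in this assay is small, estimated as a number 5 percentage points higher from compound 1 to compound 4 (within the scatter) and not clearly beyond the scatter. Compound 4 is expected at 9% with 2% to 28% as the estimated range.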

Compound 4, percent of the compound remaining: 10%
Estimate against measurement, compound 4: 1 percentage points below; low and high end bracket the measured number.
By their numbers in this assay, from the lowest: compounds 1 and 4 (each within the scatter of the next); then compound 2; then compound 3.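

In this assay, going by these compounds alone, the change from 4-isopropylpiperazin-1-yl to 4-methylpiperazin-1-yl gives a number 6 percentage points higher from compound 1 to compound 4 (within the scatter), the first measured step on the amine nitrogen in a ring. Going from isopropyl with 3 heavy atoms to methyl with 1 heavy atom therefore does not separate the two compounds on the core of compound 1, and this step has none of the size of a number 39 percentage points higher from compound 2 to compound 3 (beyond the scatter), which lies at another place in the structure. Nothing at hand bears on the reason for this result.

Left open is whether a group of another kind on this ring nitrogen, such as an acetyl, a cyclopropyl or a longer chain ending in a hydroxyl, would move the read-out beyond the scatter on the core of compound 1. Also open, as far as these compounds go, is whether methyl in place of isopropyl at this place would give a step of similar size in a compound reading as high as compound 3, which stands at 68%, rather than on a core that reads close to the bottom of the scale.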